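Methoxy addition in a growth-inhibition series without measured activity

This account rests on a few compounds, and the source may have more. Where it says the series, first, only, none or still open, it means among the compounds named here.

The series is examined in a functional assay on NCI/ADR-RES cells (Homo sapiens) for inhibition, read by sulforhodamine B assay, with a stated time of 48 h; on this read-out lower numbers stand for stronger inhibition of growth and higher numbers for weaker inhibition of growth. Compound 1 `C=C(C)[C@@H]1CC=C(Cn2cc(COc3ccc(C4NC(=O)NC(C)=C4C(=O)OCC)cc3)nn2)CC1`, compound 2 `C=C(C)[C@@H]1CC=C(Cn2cc(COc3cccc(C4NC(=O)NC(C)=C4C(=O)OCC)c3)nn2)CC1` and compound 3 `C=C(C)[C@@H]1CC=C(Cn2cc(COc3ccccc3C3NC(=O)NC(C)=C3C(=O)OCC)nn2)CC1` differ only in where the ether-linked arm sits on the aromatic ring. In this assay compound 1 reaches only the limit > 100000 nM. Compound 2 likewise shows only the limit > 100000 nM. Compound 3 also stops at the limit > 100000 nM. Thus all values stand at the limit of > 100000 nM in this assay, at which 3 of the 3 values shown sit, and compound 2 cannot be placed relative to the others. Compound 4 `C=C(C)[C@@H]1CC=C(Cn2cc(COc3cc(C4NC(=O)NC(C)=C4C(=O)OCC)ccc3OC)nn2)CC1` is compound 2 with methoxy in place of hydrogen on an aromatic carbon. Going by the values given here, with every measured value a limit, no step can guide the expectation; no change beyond the scatter is expected, and the step from compound 2 is estimated as a step that the limit leaves unreadable from compound 2 to compound 4. Compound 4 is therefore expected near 150000 nM, within 50000 nM to 500000 nM, most probably reported again as a limit.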

Compound 4, concentration for total growth inhibition: > 100000 nM
Compound 4 was reported as a limit; the forecaster's own chance of this, stated with the estimate: 85%; the middle value does not contradict the limit.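

No step can be read between compound 2 and compound 4, as both values are limits: the limit of > 100000 nM in this assay, at which 4 of the 4 values shown sit.

The compounds shown leave open whether the place of the ether-linked arm or the methoxy group alters growth inhibition at all.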